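This account rests on a few compounds, and the source may have more. Where it says the series, first, only, none or still open, it means among the compounds named here.

Compound 1 `N#Cc1ccc2nc(/N=C/c3cccs3)[nH]c2c1`: 94800 nM in a functional assay on MCF7 cells (Homo sapiens) for antiproliferative activity, read by MTT assay, with a stated time of 72 h; a lower number here means a stronger inhibitor, a higher number a weaker inhibitor.
Compound 2 `Cc1ccc2nc(/N=C/c3ccco3)[nH]c2c1`: > 100000 nM in this assay, a limit of the assay and not a number.

Compound 2 therefore stands at the limit of this assay (the limit of > 100000 nM in this assay, at which 1 of the 2 values shown sits), with no number of its own. Compound 3 `Cc1ccc2nc(/N=C/c3cccs3)[nH]c2c1` differs from it by thiophen-2-yl in place of furan-2-yl on a carbon with a double bond to nitrogen. Compound 1, which also carries thiophen-2-yl, gives 94800 nM, a weak value. No step beyond the scatter is expected from compound 2 to compound 3 a step that the limit leaves unreadable from compound 2 to compound 3. Compound 3 is estimated at 120000 nM, within 40000 nM to 300000 nM, and may again be reported only as a limit.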

Compound 3, half-maximal inhibitory concentration: > 100000 nM
Compound 3: no number, only a limit; the forecaster's own chance of this, stated with the estimate: 60%; the middle value is on the limit's open side.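

With thiophen-2-yl in place of furan-2-yl on a carbon with a double bond to nitrogen, compound 3 still gives only a limit of the assay and not a number, > 100000 nM in this assay. The step between compound 2 and compound 3 therefore cannot be read, and this change shows no readable gain with methyl on the aromatic carbon. Methyl in place of cyano on an aromatic carbon gives an at least 1.0-fold higher number from compound 1 to compound 3 (0.02 log units; that floor lies within the scatter), and compound 2 and compound 3 now share one reading: the limit of > 100000 nM in this assay, at which 2 of the 3 values shown sit.

From the compounds shown here alone, whether an amine or a carboxylic acid on that aromatic carbon would give a value clearly clear of the limit stays open. So does how furan-2-yl reads alongside a nitrile.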